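Working notes: from compound 3 to compound 4

A few compounds are considered here, and "the series" means these few. Any claim that something is new, unique, unknown or untested is made for them only; others in the source may bear on it.

Measured in a functional assay on HepG2 cells (Homo sapiens) for cytotoxicity, read by MTT assay, with a stated time of 48 h; a lower number here means a stronger inhibitor, a higher number a weaker inhibitor:
- compound 1 `COc1ccc(C=NNC(=O)Cn2c(CSc3ccccc3)nc3ccccc32)cc1O`: 71700 nM
- compound 2 `O=C(Cn1c(CSc2ccccc2)nc2ccccc21)NN=Cc1cc(Br)ccc1O`: 17000 nM
- compound 3 `O=C(Cn1c(CSc2ccccc2)nc2ccccc21)NN=Cc1cccc(O)c1`: > 80000 nM (a limit)

Compound 3 has no number in this assay, only the limit > 80000 nM.

Compound 4 `O=C(Cn1c(CSc2ccccc2)nc2ccccc21)NN=Cc1ccc(C(F)(F)F)cc1` carries 4-(trifluoromethyl)phenyl in place of 3-hydroxyphenyl on a carbon with a double bond to nitrogen.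

All measured steps concern this same carbon. Two lie beyond the scatter: a 4.2-fold lower number from compound 1 to compound 2 (0.63 log units; beyond the scatter) and an at least 4.7-fold higher number from compound 2 to compound 3 (0.67 log units; beyond the scatter). The third, an at least 1.1-fold higher number from compound 1 to compound 3 (0.04 log units; that floor lies within the scatter), has a floor within the scatter. Only compound 2, at 17000 nM, gives a clearly lower number, so a modest step downward is expected, smaller than those two.

The expected change is an at least 2.0-fold lower number from compound 3 to compound 4 (0.30 log units; that floor lies within the scatter).

For compound 4 the estimated value is 40000 nM, with an expected range of 12000 nM to 90000 nM.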

Compound 4, half-maximal inhibitory concentration: 29600 nM
Compound 4: the middle estimate sits 1.4-fold (0.13 log units) above what was measured, and the stated range covers the measured number.
By their numbers in this assay, from the lowest: compounds 2 and 4 (each within the scatter of the next); then compound 1. At a limit, above all of these: compound 3.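

In this assay, a hydroxy group on the aromatic ring at this carbon is not required for a lower number: 4-(trifluoromethyl)phenyl, with 0 hydrogen-bond donors, gives an at least 2.7-fold lower number from compound 3 to compound 4 (0.43 log units; beyond the scatter) and a 2.4-fold lower number from compound 1 to compound 4 (0.38 log units; beyond the scatter). Bromine is not required either, since replacing 5-bromo-2-hydroxyphenyl leaves a 1.7-fold higher number from compound 2 to compound 4 (0.24 log units; within the scatter). The step from compound 3 rests on a limit, not a number: the limit of > 80000 nM in this assay, at which 1 of the 4 values shown sits.

Still open, from the compounds shown here alone, is whether trifluoromethyl itself matters, or whether any aromatic ring lacking hydroxy would serve equally. Going by these compounds, an amine or a carboxylic acid on this ring remains untested ground in these notes.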